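Swapping an Ester End for a Methoxyphenyl End

The compounds below may be only part of what the source reports. "The series", "measured", "known", "first", "only" and "open" are said of these compounds alone.

Three compounds sharing one core, compound 1 `COC(=O)/C=C/c1cccc(N(Cc2ccc(/C=C/c3ccccn3)cc2)C(=O)C2CCCCC2)c1`, compound 2 `COC(=O)/C=C/c1cccc(N(Cc2ccc(-c3ccc(OC)cc3)cc2)C(=O)C2CCCCC2)c1` and compound 3 `COC(=O)/C=C/c1ccc(CN(C(=O)C2CCCCC2)c2cccc(/C=C/C(=O)OC)c2)cc1`, were tested in an assay on isolated protein with Bile acid receptor (Homo sapiens) as the target; on this read-out higher numbers stand for an effect only at larger amounts of compound and lower numbers for an effect already at smaller amounts. Compound 1 gives 309 nM and compound 2 gives 89 nM. Compound 3 reaches only the limit of this assay, > 1000 nM, so it stands without a number (the limit of > 1000 nM in this assay, at which 1 of the 3 values shown sits). Compound 4 `COC(=O)/C=C/c1cccc(N(Cc2ccc(/C=C/c3ccc(OC)cc3)cc2)C(=O)C2CCCCC2)c1` differs from compound 3 in one place: 4-methoxyphenyl in place of methoxycarbonyl on a double-bonded chain carbon bound to a double-bonded chain carbon. Among the measured compounds shown here, two measured steps bear on this. The change an at least 3.2-fold higher number from compound 1 to compound 3 (0.51 log units; beyond the scatter) is the reverse kind of swap on the same chain carbon, and the change an at least 11-fold higher number from compound 2 to compound 3 (1.05 log units; beyond the scatter) brings in the 2-(methoxycarbonyl)ethenyl group. Both raised the number when methoxycarbonyl entered, so its leaving is expected to lower it, by an at least 6.6-fold lower number from compound 3 to compound 4 (0.82 log units; beyond the scatter). Compound 4 is therefore estimated at 150 nM, within a range of 50 nM to 600 nM.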

Compound 4, half-maximal effective concentration: 208 nM
For compound 4 the middle estimate is 1.4-fold (0.14 log units) below the measured one; measured number inside the range.
By their numbers in this assay, from the lowest: compound 2; then compounds 4 and 1 (each within the scatter of the next). At a limit, above all of these: compound 3.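

Replacing methoxycarbonyl with 4-methoxyphenyl on this chain carbon gives an at least 4.8-fold lower number from compound 3 to compound 4 (0.68 log units; beyond the scatter) as a bound only, as compound 3 stands at a limit of the assay: the limit of > 1000 nM in this assay, at which 1 of the 4 values shown sits. Pyridin-2-yl and 4-methoxyphenyl at this carbon cannot be told apart, with a 1.5-fold lower number from compound 1 to compound 4 (0.17 log units; within the scatter). The ethenyl link makes a modest difference, since 2-(4-methoxyphenyl)ethenyl in place of 4-methoxyphenyl on the aromatic carbon gives a 2.3-fold higher number from compound 2 to compound 4 (0.37 log units; beyond the scatter).

Going by these compounds, what a carboxylic acid or an amine at this chain carbon would do stays open. So does the effect of a longer chain between the aromatic carbon and the 4-methoxyphenyl end.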